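From Methyl to Cyclopropyl on an Aromatic Nitrogen

The source may report more compounds than this note shows. Statements on the series, on what has been measured and on what is new or still open speak of the compounds shown alone.

- compound 1 `Cn1cccc(NCc2cc3cc(Cl)ccc3[nH]c2=O)c1=O`: 90%
- compound 2 `C[C@H](Nc1ccc(C#N)n(C)c1=O)c1cc2cc(Cl)c(OCc3ccccn3)cc2[nH]c1=O`: 66%
- compound 3 `Cn1c(C#N)ccc(NCc2cc3cc(Cl)ccc3[nH]c2=O)c1=O`: 99%

In an ADME assay on microsomes from liver (Homo sapiens) for metabolic stability, with a stated time of 30 min (on this read-out higher numbers stand for a more stable compound and lower numbers for a less stable compound), compound 1 gives 90% and sits at the upper end of the three numbers, within the scatter of compound 3. Compound 2 lies furthest from it, and its 66% is lower than compound 1 by more than the scatter.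

The next compound to be measured is compound 4 `O=c1[nH]c2ccc(Cl)cc2cc1CNc1cccn(C2CC2)c1=O`, which carries cyclopropyl in place of methyl on an aromatic nitrogen of the six-membered aromatic ring with 1 nitrogen: cyclopropyl in place of methyl on an aromatic nitrogen.

Among the measured compounds shown here, only one measured step bears on this change, and only indirectly. It shows a number 9 percentage points higher from compound 1 to compound 3 (within the scatter), with cyano in place of hydrogen on an aromatic carbon. That step sits at a different place, so it says little beyond showing that the core of compound 1 has tolerated one change in this read-out. For the measured compounds named here, no measured pair varies the group on the aromatic nitrogen, and compound 2 differs from compound 1 in more than one place.

No shift beyond the scatter is therefore expected in this assay, though a small loss would not surprise. The expected step is a number 5 percentage points lower from compound 1 to compound 4 (within the scatter). Compound 4 is estimated at 85%, with an expected range of 68% to 98%.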

Compound 4, percent of the compound remaining in the Homo sapiens assay: 78%
Beside the measured number, compound 4's estimate is 7 percentage points above it, and the stated range covers the measured number.
By their numbers in the Homo sapiens assay, from the lowest: compound 2; then compound 4; then compounds 1 and 3 (each within the scatter of the next).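

The group on the aromatic nitrogen is not a neutral position in the Homo sapiens assay, where compound 1 gives 90% and compound 4 gives 78%: the change gives a number 12 percentage points lower from compound 1 to compound 4 (beyond the scatter), whereas the change on an aromatic carbon gave a number 9 percentage points higher from compound 1 to compound 3 (within the scatter). In a physicochemical assay for solubility (a lower number here means a less soluble compound, a higher number a more soluble compound), the same replacement of methyl by cyclopropyl leaves the number in place: compound 1 gives 54000 nM, compound 4 gives 56000 nM, and the step is a 1.0-fold higher number from compound 1 to compound 4 (0.02 log units; within the scatter), so only the Homo sapiens assay separates these compounds. Nothing in the data shown offers a reason for the lower number in the Homo sapiens assay or for its absence in the physicochemical assay.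

As far as these compounds go, with only methyl and cyclopropyl compared on this nitrogen, it remains open whether the lower number follows the three-membered ring itself or simply the larger group, a question that an ethyl or isopropyl group, or a longer chain ending in a hydroxyl, could help to separate. From the compounds shown here alone, it is also open whether cyclopropyl in place of methyl would have a step of similar size on compound 3, which carries the cyano group.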